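The source may hold more compounds than are shown below. What is called first, only, known or untested is meant among the compounds shown, and "the series" means these compounds.

Compound 2, `Nc1ccccc1NC(=O)c1ccc(CSC(=S)N2CCN(Cc3ccncc3)CC2)cc1`, is the stronger of the two measured compounds: in a functional assay on HeLa cells (Homo sapiens) for antiproliferative activity, read by CCK-8 assay, with a stated time of 72 h, tested at 2 uM (a higher number here means a stronger effect of the compound at the concentration tested, a lower number a weaker effect), compound 2 gives 59.5%. Compound 1, `Nc1ccccc1NC(=O)c1ccc(CSC(=S)N2CCc3cc([N+](=O)[O-])ccc32)cc1`, is built around the same shared core but carries a different group on the dithiocarbamate nitrogen; in this assay compound 1 gives 32.6%, a number lower than that of compound 2 by more than the usual scatter. Among the compounds with values here, no pair of measured compounds differs in a single place, so no step can be read directly from the data.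

Compound 3, `Nc1ccccc1NC(=O)c1ccc(CSC(=S)N2CCN(c3ncccn3)CC2)cc1`, keeps the ring of compound 2 and changes only the group on its ring nitrogen: pyrimidin-2-yl in place of (pyridin-4-yl)methyl on an amine nitrogen in a ring. Since nothing measured tells how this assay responds to such a change, the expectation rests on the value of compound 2 alone. It is expected that the change lowers the inhibition somewhat, though the step may not exceed the scatter; the estimated step is a number 9.5 percentage points lower from compound 2 to compound 3 (within the scatter). Compound 3 is therefore estimated at 50%, with a likely range from 30% to 70%.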

Compound 3, a percentage reported as inhibition, at one concentration (the size of the read-out at that concentration, not a potency): 52.2%
Compound 3: middle estimate off by 2.2 percentage points, on the low side, within the range that was stated.
By their numbers in this assay, from the lowest: compound 1; then compounds 3 and 2 (each within the scatter of the next).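

In this assay, within the data shown here, the change on the amine nitrogen in the ring gives the first step that can be read in a single place, a number 7.3 percentage points lower from compound 2 to compound 3 (within the scatter), and that step lies within the scatter. This position therefore accepts pyrimidin-2-yl in place of (pyridin-4-yl)methyl without a change that this read-out can separate, even though the six-membered aromatic ring gains a second hetero atom and the entering group is attached directly rather than through the methyl carbon. Nothing measured on these compounds accounts for this result, and no cause can be assigned to it.

The compounds shown leave open whether an aromatic ring is needed on this nitrogen at all, since a plain methyl, an acetyl or a 2-hydroxyethyl group could tell how the inhibition responds without one. Among these compounds, they also leave open how much of the gap between compound 1 and the other two compounds belongs to any one structural feature, since compound 1 differs from them in more than one place and no single step connects it to either.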